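Lengthening the side chain of compound 2

A few compounds are considered here, and "the series" means these few. Any claim that something is new, unique, unknown or untested is made for them only; others in the source may bear on it.

Among the compounds with values here, compound 1 `CCCCC(C#CC(=O)OC)O/C=C/C(=O)OC` gives 250 nM in a functional assay on HBL-100 cells (Homo sapiens) for antiproliferative activity, read by sulforhodamine B assay, with a stated time of 48 h (on this read-out higher numbers stand for weaker inhibition of growth and lower numbers for stronger inhibition of growth), and compound 2 `CCC(C#CC(=O)OC)O/C=C/C(=O)OC` gives 320 nM on the same read-out, so compound 2 sits level with the only other measured compound. Compound 3 `COC(=O)C#CC(CC(C)C)O/C=C/C(=O)OC` has isopropyl in place of methyl on a saturated chain carbon of compound 2 (isopropyl in place of methyl on a saturated chain carbon, two bonds along the chain from an oxygen on an unsaturated carbon and a triple-bonded carbon). Within the data shown here, the one measured change to this chain (a 1.3-fold higher number from compound 1 to compound 2 (0.11 log units; within the scatter)) stayed within the scatter, so no step beyond the scatter is expected in this assay here. The estimated step is small (a 1.1-fold lower number from compound 2 to compound 3 (0.06 log units; within the scatter)). Compound 3 is expected at 280 nM (estimated range 130 nM to 600 nM).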

Compound 3, concentration for 50% growth inhibition: 330 nM
Compound 3: the middle estimate sits 1.2-fold (0.07 log units) below what was measured, and the stated range covers the measured number.
By their numbers in this assay, from the lowest: compounds 1, 2 and 3 (each within the scatter of the next).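

Replacing methyl with isopropyl on this saturated chain carbon, a larger and branched group, leaves the result in this assay within the scatter (a 1.0-fold higher number from compound 2 to compound 3 (0.01 log units; within the scatter)). Isopropyl in place of propyl at the same carbon also stays within the scatter (a 1.3-fold higher number from compound 1 to compound 3 (0.12 log units; within the scatter)), so among these three compounds, the branched chain of compound 3 reads the same as the unbranched chains of compound 1 and compound 2. No measurement offers a reason for this. As far as these compounds go, whether a much longer chain such as octyl, or a chain ending in an amine or a carboxylic acid, would give a step beyond the scatter remains open.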